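Methoxy additions in a series held at the assay limit

A few compounds are considered here, and "the series" means these few. Any claim that something is new, unique, unknown or untested is made for them only; others in the source may bear on it.

Measured compounds:
Compound 1 `COc1ccc(/C=C/C2(C)C=CC(=O)O2)c(OC)c1` gives in a functional assay on K562 cells (Homo sapiens) for inhibition, read by sulforhodamine B assay, with a stated time of 48 h (a higher number here means a weaker inhibitor of growth, a lower number a stronger inhibitor of growth), the value > 1000000 nM, which is a limit of the assay and not a number.
Compound 2 `COc1ccc(/C=C/C2(C)C=CC(=O)O2)cc1OC` gives in this assay the value > 1000000 nM, again a limit.
Compound 3 `COc1cc(/C=C/C2(C)C=CC(=O)O2)cc(OC)c1OC` gives in this assay the value > 1000000 nM, also a limit.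

Compound 1 and compound 2 have the same atoms joined differently; the difference between the two cores is not broken down here. From compound 2 to compound 3 the change is methoxy in place of hydrogen on an aromatic carbon. The step that the two limits leave unreadable from compound 2 to compound 3 cannot be read because the limit of > 1000000 nM in this assay, at which 3 of the 3 values shown sit, covers both of its ends.

Compound 4 `COc1cc(OC)c(/C=C/C2(C)C=CC(=O)O2)c(OC)c1` is not yet measured and differs from compound 1 by methoxy in place of hydrogen on an aromatic carbon. This is the same kind of change as from compound 2 to compound 3, not the same: here the place is ortho to a group of 9 heavy atoms and meta to two methoxy groups, whereas in compound 3 it is ortho to a methoxy group, meta to a group of 9 heavy atoms and meta to a methoxy group.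

The step from compound 1 is expected to be a number no higher from compound 1 to compound 4 (the limit leaves the size open), resting on (the limit of > 1000000 nM in this assay, at which 3 of the 3 values shown sit). For compound 4 the estimate is 1000000 nM, expected between 300000 nM and 3000000 nM, most likely reported as a limit rather than a number.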

Compound 4, concentration for total growth inhibition: > 1000000 nM
Compound 4: no number, only a limit (the forecaster's own chance of this, stated with the estimate: 90%); the middle value sits exactly at the limit.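

No new step can be read from compound 1 to compound 4, as both results are limits of the assay and not numbers: the limit of > 1000000 nM in this assay, at which 4 of the 4 values shown sit.

The compounds shown leave open how far beyond the limit each of the four lies, and so whether the number or place of the methoxy groups makes any difference to growth inhibition.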